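The source may report more compounds than this note shows. Statements on the series, on what has been measured and on what is new or still open speak of the compounds shown alone.

Working notes on the series. Among the compounds with values here, compound 3 `C[C@@H](NC1CCN(CCCc2c[nH]c3ccc(-n4cnnc4)cc23)CC1)c1ccccc1` gives 13 nM in an assay on CHO cells for agonist activity at 5-hydroxytryptamine receptor 1D (Homo sapiens), read by GTPgammaS binding (on this read-out lower numbers stand for an effect already at smaller amounts and higher numbers for an effect only at larger amounts of compound), the highest of the three numbers so far: compound 2 `c1ccc(CNC2CCN(CCCc3c[nH]c4ccc(-n5cnnc5)cc34)CC2)cc1` gives 7.6 nM and the gap a 1.7-fold higher number from compound 2 to compound 3 (0.23 log units; within the scatter) stays within the scatter, while compound 1 `c1ccc(CNCC2CCN(CCCc3c[nH]c4ccc(-n5cnnc5)cc34)CC2)cc1` gives 5.6 nM and the gap a 2.3-fold higher number from compound 1 to compound 3 (0.37 log units; beyond the scatter) is beyond it.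

Compound 4 `c1ccc2c(c1)CCC2NCC1CCN(CCCc2c[nH]c3ccc(-n4cnnc4)cc23)CC1` is not yet measured. The change from compound 3 is ((2,3-dihydro-1H-inden-1-yl)amino)methyl in place of (1-phenylethyl)amino on a saturated ring carbon. It does two things at once: it puts back the methylene spacer between the saturated ring and the amine, as in compound 1, and it closes the benzylic methyl of compound 3 into a five-membered non-aromatic ring.

Within the data shown here, the steps that bear on it are a 2.3-fold higher number from compound 1 to compound 3 (0.37 log units; beyond the scatter), which covers spacer and methyl together, a 1.7-fold higher number from compound 2 to compound 3 (0.23 log units; within the scatter), for the methyl alone, and a 1.4-fold higher number from compound 1 to compound 2 (0.13 log units; within the scatter), for the spacer alone. Restoring the spacer is expected to return most of the small loss seen in compound 3; the ring closure has no precedent here. The expectation for compound 4 in this assay is therefore a step of a 1.9-fold lower number from compound 3 to compound 4 (0.27 log units; within the scatter), downward, close to the value of compound 1. Compound 4 is estimated at 7 nM, with a range of 3 nM to 18 nM.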

Compound 4, half-maximal effective concentration: 1.3 nM
For compound 4 the middle estimate is 5.4-fold (0.73 log units) above the measured one; measured number below the stated range.
By their numbers in this assay, from the lowest: compound 4; then compounds 1, 2 and 3 (each within the scatter of the next, the first and the last beyond it).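

In this assay, within the data shown here, the one-place change on the amine nitrogen, 2,3-dihydro-1H-inden-1-yl in place of benzyl, gives a 4.3-fold lower number from compound 1 to compound 4 (0.63 log units; beyond the scatter), a larger step than any among the earlier compounds, so this nitrogen substituent can shift the number well beyond the scatter. The wider replacements point the same way, with a 5.8-fold lower number from compound 2 to compound 4 (0.77 log units; beyond the scatter) and a 10-fold lower number from compound 3 to compound 4 (1.00 log units; beyond the scatter), which leaves compound 4 with the lowest number of the four; tying the benzylic carbon into the five-membered non-aromatic ring thus goes with a clear drop, whereas the open methyl alone gave only a 1.7-fold higher number from compound 2 to compound 3 (0.23 log units; within the scatter). No supporting data bear on the cause of these steps.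

The compounds shown leave open how the two mirror-image forms of the 2,3-dihydro-1H-inden-1-yl group compare, since compound 4 carries no defined stereocentre in that group, while compound 3 does in its (1-phenylethyl)amino group. Also open, going by these compounds, is whether a 1,2,3,4-tetrahydronaphthalen-1-yl group on the same amine nitrogen, or a 2,3-dihydro-1H-inden-1-yl group on the amine without the methylene spacer, would keep the low number.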